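Hydroxyalkylamino series: moving the hydroxyl one carbon out

This account rests on a few compounds, and the source may have more. Where it says the series, first, only, none or still open, it means among the compounds named here.

Measured compounds:
compound 1 `CNc1nc(-c2ccccc2)nc2c1nnn2Cc1ccccc1F` — 25 nM in an assay on Cerebral cortex for displacement of a labelled ligand from adenosine receptor A1 (Bos taurus); on this read-out higher numbers stand for weaker inhibition and lower numbers for stronger inhibition
compound 2 `CC(O)CNc1nc(-c2ccccc2)nc2c1nnn2Cc1ccccc1F` — 4.8 nM in this assay

Compound 2 gives the lowest of the two numbers in this assay; its nearest neighbour is compound 1, and the step of a 5.2-fold lower number from compound 1 to compound 2 (0.72 log units; beyond the scatter) lies beyond the scatter.

Compound 3 `OCCCNc1nc(-c2ccccc2)nc2c1nnn2Cc1ccccc1F` is not yet measured. Its change from compound 2 is 2-hydroxyethyl in place of 1-hydroxyethyl on a saturated chain carbon bound to a nitrogen on an aromatic ring. The two compounds hold the same atoms joined differently, so the hydroxyl is relocated along the chain rather than added or removed.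

Among the measured compounds shown here, the only measured step, a 5.2-fold lower number from compound 1 to compound 2 (0.72 log units; beyond the scatter), concerns adding the hydroxyl-bearing fragment onto the chain, not relocating the hydroxyl within it. It shows that the number fell when that fragment was introduced, but gives no direct read on where along the chain the hydroxyl should sit. Shifting the hydroxyl by one carbon is expected to change the number little, so the expected step of a 1.3-fold higher number from compound 2 to compound 3 (0.10 log units; within the scatter) lies within the scatter. Compound 3 is therefore expected to give 6 nM in this assay, with a range from 2.5 nM to 15 nM.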

Compound 3, inhibition constant: 3.7 nM
The estimate for compound 3 lay 1.6-fold (0.21 log units) above the measured number; the range from low to high includes it.
By their numbers in this assay, from the lowest: compounds 3 and 2 (each within the scatter of the next); then compound 1.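

In this assay, among the compounds shown here, the change from 2-hydroxypropyl to 3-hydroxypropyl gives a 1.3-fold lower number from compound 2 to compound 3 (0.11 log units; within the scatter) and so leaves the two hydroxyl placements on this chain indistinguishable, a reading that the earlier compounds, with only one placement, could not give. The step beyond the scatter seen on going from the methyl-bearing amine to a hydroxyl-bearing chain also holds for the second placement, with a 6.8-fold lower number from compound 1 to compound 3 (0.83 log units; beyond the scatter) in the same direction as the earlier step, so at this position that fall is not tied to one of these two placements. Nothing measured here bears on why the hydroxyl's place along the chain makes so little difference.

Still open, from the compounds shown here alone, is whether the fall from compound 1 belongs to the hydroxyl itself or to the longer chain that carries it, a question that a plain propyl chain on the same amine would separate. Also open, going by these compounds, is how far this indifference to placement extends, for which a 4-hydroxybutyl chain or a methoxy group in place of the hydroxyl would be the next points of comparison.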